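Para-substituent swap on the anilide of compound 3

The source may report more compounds than this note shows. Statements on the series, on what has been measured and on what is new or still open speak of the compounds shown alone.

Measured so far in a functional assay on MGC-803 cells (Homo sapiens) for inhibition, read by MTT assay, with a stated time of 72 h; on this read-out lower numbers stand for stronger inhibition and higher numbers for weaker inhibition:
compound 1 `O=C(CSc1nc(Nc2ccccc2)c2ccccc2n1)Nc1cccc(F)c1` gives 12700 nM;
compound 2 `CCc1cccc(NC(=O)CSc2nc(Nc3ccccc3)c3ccccc3n2)c1` gives 15800 nM;
compound 3 `O=C(CSc1nc(Nc2ccccc2)c2ccccc2n1)Nc1ccc(F)cc1` gives > 50000 nM.

For compound 3 the figure is not a number but a limit of this assay (the limit of > 50000 nM in this assay, at which 1 of the 3 values shown sits). Compound 3 therefore sits at the weak end of the three; the step of an at least 3.9-fold higher number from compound 1 to compound 3 (0.59 log units; beyond the scatter) and the step of an at least 3.1-fold higher number from compound 2 to compound 3 (0.50 log units; beyond the scatter) are both beyond the scatter, whereas a 1.2-fold higher number from compound 1 to compound 2 (0.09 log units; within the scatter) stays within it.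

Compound 4 `O=C(CSc1nc(Nc2ccccc2)c2ccccc2n1)Nc1ccc(C(F)(F)F)cc1` is the next member. The change from compound 3 is trifluoromethyl in place of fluoro on an aromatic carbon. For the measured compounds named here, none of the measured steps covers trifluoromethyl against fluoro on the anilide ring. What is known is only that 4-fluorophenyl reads weaker than either 3-fluorophenyl or 3-ethylphenyl, and that on the 3-substituted ring a change from fluoro to ethyl gave no shift beyond the scatter. The trifluoromethyl group enters at the same place on the ring as the fluoro it replaces, so no recovery is expected; the result is expected to remain near the limit.

Compound 4 is estimated at 50000 nM with a range from 15000 nM to 160000 nM. The expected step is a number no higher from compound 3 to compound 4 (the limit leaves the size open), that is, no change beyond the scatter.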

Compound 4, half-maximal inhibitory concentration: 8670 nM
The estimate for compound 4 lay 5.8-fold (0.76 log units) above the measured number; the measured number lies below the stated range.
By their numbers in this assay, from the lowest: compounds 4, 1 and 2 (each within the scatter of the next). At a limit, above all of these: compound 3.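

In this assay, trifluoromethyl in place of fluoro gives an at least 5.7-fold lower number from compound 3 to compound 4 (0.76 log units; beyond the scatter), so the weak reading of the 4-fluorophenyl anilide does not hold for every group at this place on the ring. Compound 3 stands at a limit and not at a number: the limit of > 50000 nM in this assay, at which 1 of the 4 values shown sits. With the 4-(trifluoromethyl)phenyl anilide, the ring no longer separates from the two 3-substituted anilides, as a 1.8-fold lower number from compound 2 to compound 4 (0.26 log units; within the scatter) and a 1.5-fold lower number from compound 1 to compound 4 (0.17 log units; within the scatter) show, which leaves compound 3 as the only one of the four apart from the rest.

Fluoro and trifluoromethyl are the only two groups shown at this place, and two groups make no trend, so what separates them cannot be read from these data. A methyl, a chloro or a methoxy group on the same carbon would show whether fluoro is the exception or trifluoromethyl is.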